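Pyridine carboxamide isomers: cytotoxicity notes

The source may report more compounds than this note shows. Statements on the series, on what has been measured and on what is new or still open speak of the compounds shown alone.

Measured so far:
compound 1 `CONC(=O)c1ccccn1` — > 1000000 nM
compound 2 `O=C(NO)c1cccnc1` — 450000 nM

In an ADME assay on Huh-7 cells (Homo sapiens) for cytotoxicity, read by MTT assay, with a stated time of 72 h (a higher number here means that more compound is tolerated, a lower number that less compound is tolerated), compound 1 gives > 1000000 nM, which is a limit of the assay and not a number. Compound 1 therefore stands at the limit of > 1000000 nM in this assay, at which 1 of the 2 values shown sits, so its true position on the scale is open. Compound 2 gives 450000 nM in this assay.

Compound 3 `CN(O)C(=O)c1ccccn1` is not yet measured in this assay. It differs from compound 1 in one place: hydroxy(methyl)amino in place of methoxyamino on a carbonyl carbon. Among the compounds with values here, no step between measured compounds is available, so any step from compound 1 to compound 3 rests on expectation alone. The expectation is for no step beyond the usual scatter, or at most a small one towards less tolerated compound, with a fair chance that the assay again returns only a limit. Compound 3 is expected to give 700000 nM in this assay, within 250000 nM to 1000000 nM. The expected step is an at least 1.4-fold lower number from compound 1 to compound 3 (0.15 log units; that floor lies within the scatter).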

Compound 3, half-maximal cytotoxic concentration: > 1000000 nM
Compound 3: only a limit was reported; the forecaster's own chance of this, stated with the estimate: 45%; at least 1.4-fold (0.15 log units) between middle value and limit.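

Compound 1 and compound 3 both return only a limit in this assay, so no step can be read between them: the limit of > 1000000 nM in this assay, at which 2 of the 3 values shown sit.

Still open, from the compounds shown here alone, is where either compound truly stands on this scale, and whether hydroxy(methyl)amino in place of methoxyamino on a carbonyl carbon shifts the value at all.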